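The source may report more compounds than this note shows. Statements on the series, on what has been measured and on what is new or still open speak of the compounds shown alone.

Compound 3 `C[C@@H](O[C@H]1CC[C@]2(CC1)COC(C)(C)C2)c1nc(-c2ccc(CS(C)(=O)=O)c(F)c2)no1` gives 106% in a functional assay on HEK293 cells for agonist activity at Glucose-dependent insulinotropic receptor (Homo sapiens), read by cAMP accumulation, with a stated time of 30 min; a higher number here means a larger maximal response, a lower number a smaller maximal response. Compound 2 `C[C@H](O[C@H]1CC[C@]2(CC1)COC(C)(C)C2)c1nc(-c2ccc(CS(C)(=O)=O)c(F)c2)no1` gives 106% in this assay, and compound 1 `CC(O[C@H]1CC[C@]2(CC1)COC(C)(C)C2)c1nc(-c2ccc(CS(C)(=O)=O)c(F)c2)no1` gives 130%. The steps of a number 24 percentage points lower from compound 1 to compound 3 (beyond the scatter) and a number 24 percentage points lower from compound 1 to compound 2 (beyond the scatter) are the only moves beyond the scatter, while no change at the digits printed from compound 2 to compound 3 (within the scatter). Compounds 2 and 3 thus stand together as the lowest pair of the three, with compound 1 above both.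

Compound 4 `C[C@@H](O[C@H]1CC[C@]2(CC1)COC(C)(C)C2)c1nc(-c2cc(F)c(CS(C)(=O)=O)cc2F)no1` differs from compound 3 by fluoro in place of hydrogen on an aromatic carbon. None of the three measured steps involves a change of this kind; all three concern configuration as drawn, so they offer no guide to the size or direction of this substitution. Among the compounds with values here, with no relevant precedent, the expected step is no change at the digits printed from compound 3 to compound 4 (within the scatter), within the scatter. Compound 4 is therefore estimated at 106% in this assay, between 88% and 125%.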

Compound 4, largest response reached (reported as percent of maximum), in percent of the reference or control that the assay uses: 118%
The estimate for compound 4 lay 12 percentage points below the measured number, within the range that was stated.
By their numbers in this assay, from the lowest: compounds 2 and 3 (each within the scatter of the next); then compound 4; then compound 1.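

Fluoro in place of hydrogen on this aromatic carbon, ortho to a large group and para to a fluoro group, is the only change shown that is not one of configuration as drawn, and in this assay it gives a number 12 percentage points higher from compound 3 to compound 4 (beyond the scatter) on the same core. The maximal response therefore shifts with substitution at this position, not only with configuration. What is known about these compounds gives no cause for this step.

Going by these compounds, whether chloro, methoxy or a nitrile at this position would move the response the same way remains open. So does whether fluoro here gives a similar step on the configuration of compound 2.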